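Chloro added beside trifluoromethyl on a pyridyl piperidine thiourea

The source may hold more compounds than are shown below. What is called first, only, known or untested is meant among the compounds shown, and "the series" means these compounds.

Three thioureas were measured in an assay on membranes from brain for binding affinity to Lysophosphatidylserine lipase ABHD12 (Mus musculus), read by fluorescence, with a stated time of 20 min; a higher number here means a weaker inhibitor, a lower number a stronger inhibitor. Compound 1 `FC(F)(F)c1cnc(N2CCC(NC(=S)Nc3cccnc3)CC2)c(Cl)c1` gives 1100 nM, compound 2 `FC(F)(F)c1ccnc(N2CCC(NC(=S)Nc3cccnc3)CC2)c1` gives 640 nM, and compound 3 `FC(F)(F)c1ccc(N2CCC(NC(=S)Nc3cccnc3)CC2)nc1` gives 1900 nM. Compound 1 differs from compound 3 by chloro in place of hydrogen on an aromatic carbon, a step of a 1.7-fold lower number from compound 3 to compound 1 (0.24 log units; within the scatter). How the cores of compound 2 and compound 3 differ is not broken down here. Compound 4 `FC(F)(F)c1ccnc(N2CCC(NC(=S)Nc3cccnc3)CC2)c1Cl`, not yet measured, differs from compound 2 by chloro in place of hydrogen on an aromatic carbon, the same kind of change, though here ortho to a trifluoromethyl group rather than meta to it. Resting on compound 3 and compound 1 with a 1.7-fold lower number from compound 3 to compound 1 (0.24 log units; within the scatter), the step from compound 2 to compound 4 is expected to be a 1.4-fold lower number from compound 2 to compound 4 (0.15 log units; within the scatter). Compound 4 is estimated at 450 nM, within 180 nM to 1100 nM in this assay .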

Compound 4, half-maximal inhibitory concentration: 300 nM
For compound 4 the middle estimate is 1.5-fold (0.18 log units) above the measured one; the measured number falls inside the stated range.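

In this assay, chloro in place of hydrogen on an aromatic carbon gives a 2.1-fold lower number from compound 2 to compound 4 (0.33 log units; beyond the scatter), and this step does not differ from the one seen on the other core: the same change on two cores in this assay, a 1.7-fold lower number (0.24 log units; within the scatter) from compound 3 to compound 1 and a 2.1-fold lower number (0.33 log units; beyond the scatter) from compound 2 to compound 4, 1.2-fold (0.09 log units) apart, within the scatter of two such steps. The change therefore points the same way on both cores, with steps of similar size. Within the data shown here, this does not make it a rule for the series: it rests on only two cores, only the step to compound 4 lies beyond the scatter, and only compound 4 carries its chloro ortho to a trifluoromethyl group, so any influence of place remains unresolved.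

As far as these compounds go, whether a bromo, a methyl or a nitrile in place of the chloro would give a similar step remains open. So does whether the chloro step would hold with a urea in place of the thiourea.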